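Trading Methylamino for Methyl in a Potent Compound

This account rests on a few compounds, and the source may have more. Where it says the series, first, only, none or still open, it means among the compounds named here.

Compound 1 `CNc1nc(-c2cc(OC)c(OC)c(OC)c2)c(-c2ccc(C(F)(F)F)cc2)s1` and compound 2 `CCOc1ccc(-c2sc(NC)nc2-c2cc(OC)c(OC)c(OC)c2)cc1` share a core and were both measured in a functional assay on HT-29 cells (Homo sapiens) for antiproliferative activity, read by MTT assay, with a stated time of 72 h; on this read-out lower numbers stand for stronger inhibition and higher numbers for weaker inhibition. In this assay compound 1 gives 1240 nM, while compound 2 gives 3.2 nM, the lower of the two numbers. The two differ in one place, with ethoxy in place of trifluoromethyl on an aromatic carbon, and that swap produces a 390-fold lower number from compound 1 to compound 2 (2.59 log units; beyond the scatter).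

Compound 3 `CCOc1ccc(-c2sc(C)nc2-c2cc(OC)c(OC)c(OC)c2)cc1` keeps the 4-ethoxyphenyl group of compound 2 and changes a different place: methyl in place of methylamino on an aromatic carbon. Among the compounds with values here, no measured step covers this place, so the data give only indirect guidance. Within the data shown here, the one step available, a 390-fold lower number from compound 1 to compound 2 (2.59 log units; beyond the scatter), shows that a single change on this core can move the number a long way. Among the measured compounds shown here, compound 2 also holds the lowest number so far, which leaves a rise as the likelier direction. The expected change is a 9.4-fold higher number from compound 2 to compound 3 (0.97 log units; beyond the scatter), toward weaker inhibition, and its size is uncertain. Compound 3 is estimated at 30 nM, with an expected range of 5 nM to 200 nM.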

Compound 3, half-maximal inhibitory concentration: 487 nM
Compound 3: the middle estimate sits 16-fold (1.21 log units) below what was measured, and the stated range ends below it.
By their numbers in this assay, from the lowest: compound 2; then compound 3; then compound 1.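

In this assay the step from methylamino to methyl gives a 150-fold higher number from compound 2 to compound 3 (2.18 log units; beyond the scatter), so the place on the aromatic carbon next to the ring nitrogen and next to the ring sulfur can also move the number a long way, whereas the earlier step showed this only for the group on the other aromatic ring. The change is small when counted in atoms, as methylamino has 2 heavy atoms and methyl has 1, yet it costs most of the strong inhibition seen with compound 2, so a small edit at this place on the shared core is enough to matter. Methylamino also counts 1 hydrogen-bond donor and 1 hydrogen-bond acceptor where methyl counts 0 of each, but no measurement shown here tells which difference between the two groups accounts for the rise.

The compounds shown leave open whether the nitrogen alone is enough at this place, which a plain amine would test, and whether a larger group such as dimethylamino or ethylamino would be tolerated. They also leave open whether methyl has the same effect when trifluoromethyl replaces ethoxy on the other ring.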